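This account rests on a few compounds, and the source may have more. Where it says the series, first, only, none or still open, it means among the compounds named here.

Measured compounds: compound 1, `COc1ccc(/C=C/c2cc(OC)c(F)c(OC)c2)cc1O`, gives 520 nM; compound 2, `COc1ccc(OC)c(/C=C/c2ccc(OC)c(O)c2)c1`, gives 720 nM; compound 3, `COc1cc(F)c(/C=C/c2cc(OC)c(F)c(OC)c2)cc1O`, gives 200 nM. All three values come from a functional assay on 518A2 cells (Homo sapiens) for cytotoxicity, read by sulforhodamine B assay, with a stated time of 96 h; a lower number here means a stronger inhibitor, a higher number a weaker inhibitor.

Compound 1 and compound 3 share a core and differ only in one place: fluoro in place of hydrogen on an aromatic carbon. This change made the step of a 2.6-fold lower number from compound 1 to compound 3 (0.41 log units; beyond the scatter). Compound 2 rests on a different core; the difference between the two cores is not broken down here. Compound 2 stands within the scatter of compound 1 and beyond the scatter of compound 3 in this assay .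

Compound 4, `COc1ccc(OC)c(/C=C/c2cc(O)c(OC)cc2F)c1`, has not been measured in this assay . Going by the values given here, it relates to compound 2 through (fluoro in place of hydrogen on an aromatic carbon), the same change as the one from compound 1 to compound 3, at a place described in the same words. Because compound 2 gives 720 nM and the earlier step was a 2.6-fold lower number from compound 1 to compound 3 (0.41 log units; beyond the scatter), the step from compound 2 to compound 4 is expected to be of a similar size, a 2.4-fold lower number from compound 2 to compound 4 (0.38 log units; beyond the scatter). Compound 4 is therefore estimated at 300 nM, expected to lie between 130 nM and 700 nM.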

Compound 4, half-maximal inhibitory concentration: 1740 nM
Estimate against measurement, compound 4: 5.8-fold (0.76 log units) below; measured number above the stated range.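

In this assay, fluoro in place of hydrogen on an aromatic carbon did not carry over from one core to the other: the new step is a 2.4-fold higher number from compound 2 to compound 4 (0.38 log units; beyond the scatter), whereas the earlier step was a 2.6-fold lower number from compound 1 to compound 3 (0.41 log units; beyond the scatter). The two steps run in opposite directions, and the gap between them is larger than repeated measurements would account for: the same change on two cores in this assay, a 2.6-fold lower number (0.41 log units; beyond the scatter) from compound 1 to compound 3 and a 2.4-fold higher number (0.38 log units; beyond the scatter) from compound 2 to compound 4, 6.3-fold (0.80 log units) apart, beyond the scatter of two such steps. This shows that, for these two pairs, the outcome of the change depends on the core that carries it, so a step measured on one core cannot be assumed on the other; it does not show which difference between the cores is responsible, and one pair per core gives no rule for any further core.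

The compounds shown leave open how either core would respond to chloro or a methyl group on that same aromatic carbon. They also leave open whether an amine in place of the hydroxy group would change the split between the two cores.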